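The source may hold more compounds than are shown below. What is called first, only, known or untested is meant among the compounds shown, and "the series" means these compounds.

Compound 1 `O=C(/C=C/c1cccc(NC(=O)c2ccccc2Br)c1)c1nc2ccccc2[nH]1` gives 1680 nM in a functional assay on HCT-116 cells (Homo sapiens) for antiproliferative activity, read by MTT assay, with a stated time of 48 h; a higher number here means a weaker inhibitor, a lower number a stronger inhibitor. Compound 2 `O=C(Nc1cccc(/C=C/C(=O)c2nc3ccccc3[nH]2)c1)c1cccc(Br)c1` gives 1560 nM. Compound 3 `O=C(Nc1cccc(/C=C/C(=O)c2nc3ccccc3[nH]2)c1)c1cccc(C(F)(F)F)c1` gives 3360 nM.

Of the three measured numbers, compound 3 has the highest, meaning the weakest inhibition, though only one gap around it is clearly real: a 2.2-fold higher number from compound 2 to compound 3 (0.33 log units; beyond the scatter), whereas a 2.0-fold higher number from compound 1 to compound 3 (0.30 log units; within the scatter). The two bromophenyl compounds sit close together, with a 1.1-fold lower number from compound 1 to compound 2 (0.03 log units; within the scatter).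

Compound 4 `COc1ccc(C(=O)Nc2cccc(/C=C/C(=O)c3nc4ccccc4[nH]3)c2)cc1` differs from compound 3 in one place: 4-methoxyphenyl in place of 3-(trifluoromethyl)phenyl on a carbonyl carbon. Among the measured compounds shown here, the steps that bear on this are the ones that also changed the ring on that carbonyl carbon, all of which stayed small or modest. Replacing the trifluoromethyl-bearing ring by another simple phenyl ring gave a modest drop in number because of a 2.2-fold higher number from compound 2 to compound 3 (0.33 log units; beyond the scatter), and no larger move in either direction. A small step downward, or none beyond the scatter, is therefore expected in this assay.

Compound 4 is expected to give about 2000 nM, within a range of 900 nM to 4500 nM. For compound 4 this estimate means an expected step of a 1.7-fold lower number from compound 3 to compound 4 (0.23 log units; within the scatter).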

Compound 4, half-maximal inhibitory concentration: 4880 nM
Beside the measured number, compound 4's estimate is 2.4-fold (0.39 log units) below it; measured number outside the range, above it.
By their numbers in this assay, from the lowest: compounds 2, 1, 3 and 4 (each within the scatter of the next, the first and the last beyond it).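

In this assay, 4-methoxyphenyl carries a hydrogen-bond acceptor where 3-(trifluoromethyl)phenyl carries none, yet the swap on this carbonyl carbon cannot be told apart from the scatter, with a 1.5-fold higher number from compound 3 to compound 4 (0.16 log units; within the scatter). Against the two bromophenyl rings the same group does separate, with a 3.1-fold higher number from compound 2 to compound 4 (0.50 log units; beyond the scatter) and a 2.9-fold higher number from compound 1 to compound 4 (0.46 log units; beyond the scatter), which are the largest steps seen at this position, though both are still modest. Nothing available here accounts for these differences.

Every ring on this carbonyl carbon is a phenyl ring carrying one group, so the compounds shown leave open what an unsubstituted phenyl ring would give. They also leave open what a phenyl ring bearing an amine or a carboxylic acid would do, or a longer chain in place of the ring.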